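A few compounds are considered here, and "the series" means these few. Any claim that something is new, unique, unknown or untested is made for them only; others in the source may bear on it.

Measured compounds in a functional assay on HGC-27 cells (Homo sapiens) for cytotoxicity, read by MTT assay, with a stated time of 72 h; a higher number here means a weaker inhibitor, a lower number a stronger inhibitor:
compound 1, `FC(F)(F)c1ccc(CSc2nc(Nc3ccccc3Cl)c3ccccc3n2)cc1`, gives > 50000 nM, which is a limit of the assay rather than a number.
compound 2, `Fc1ccc(Nc2nc(SCc3ccc(C(F)(F)F)cc3)nc3ccccc23)cc1`, gives 19500 nM.

Within the data shown here, compound 2 thus holds the only number in this assay. The other value, that of compound 1, is a limit (the limit of > 50000 nM in this assay, at which 1 of the 2 values shown sits). Compound 3, `O=[N+]([O-])c1ccc(Nc2nc(SCc3ccc(C(F)(F)F)cc3)nc3ccccc23)cc1`, differs from compound 2 by nitro in place of fluoro on an aromatic carbon. Among the measured compounds shown here, no measured step makes this change; the single step available, an at least 2.5-fold lower number from compound 1 to compound 2 (0.40 log units; beyond the scatter), alters the group on the nitrogen in another way and bears on it only loosely. The expected step of a 1.3-fold lower number from compound 2 to compound 3 (0.11 log units; within the scatter) is therefore none beyond the scatter. Compound 3 is estimated at 15000 nM, between 4000 nM and 50000 nM.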

Compound 3, half-maximal inhibitory concentration: 16600 nM
The estimate for compound 3 lay 1.1-fold (0.04 log units) below the measured number; the range from low to high includes it.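

In this assay, the step for nitro in place of fluoro on this aromatic carbon is a 1.2-fold lower number from compound 2 to compound 3 (0.07 log units; within the scatter), so the larger group with its two hydrogen-bond acceptors leaves the result unchanged within the scatter. Moving from 2-chlorophenyl to 4-nitrophenyl gives an at least 3.0-fold lower number from compound 1 to compound 3 (0.47 log units; beyond the scatter), which adds a second 4-substituted compound to the comparison with compound 1. The value of compound 1 is a limit, so this step gives only a bound: the limit of > 50000 nM in this assay, at which 1 of the 3 values shown sits.

Going by these compounds, whether an amine or a carboxylic acid on this carbon would shift the number beyond the scatter remains open. So does the effect of a chloro group on this same carbon, which would separate the identity of the group from its place on the ring.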